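Methoxy to Chloro: Predicting the Next Measurement

This account rests on a few compounds, and the source may have more. Where it says the series, first, only, none or still open, it means among the compounds named here.

In a functional assay on the whole organism (Abdomen, strain Swiss) with Mus musculus as the target, with a stated time of 30 min (a higher number here means that more compound is needed for the effect, a lower number that less compound is needed), compound 1 `COc1ccc(/C=C/C(=O)c2ccc(NC(=S)Nc3ccc(Cl)cc3)cc2)cc1` gives 10.4 umol/kg. Among the three measured compounds it stands second highest; compound 3 `O=C(Nc1ccc(Cl)cc1)Nc1ccc(C(=O)/C=C/c2ccccc2)cc1`, with 7.25 umol/kg, lies nearest and within the scatter of it, while compound 2 `Cc1ccc(/C=C/C(=O)c2ccc(NC(=O)Nc3ccc(Cl)cc3)cc2)cc1`, with 39.7 umol/kg, lies furthest and beyond the scatter. Going by the values given here, the only single-point step among the measured compounds is a 5.5-fold lower number from compound 2 to compound 3 (0.74 log units; beyond the scatter), a hydrogen in place of methyl on an aromatic carbon of the same ring that is altered here. Compound 4 `O=C(/C=C/c1ccc(Cl)cc1)c1ccc(NC(=S)Nc2ccc(Cl)cc2)cc1` differs from compound 1 by chloro in place of methoxy on an aromatic carbon. Among the compounds with values here, no measured pair shows chloro set against methoxy, so that one step, in which a group leaving the ring went with a lower number, offers only a loose guide. Compound 4 is therefore expected to give a number near that of compound 1, with a step of a 1.3-fold lower number from compound 1 to compound 4 (0.11 log units; within the scatter) that need not exceed the scatter. The estimated value of compound 4 in this assay is 8 umol/kg, with a likely range from 3 umol/kg to 22 umol/kg.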

Compound 4, dose for 50% inhibition: 7.59 umol/kg
Compound 4: middle estimate off by 1.1-fold (0.02 log units), on the high side; measured number inside the range.
By their numbers in this assay, from the lowest: compounds 3, 4 and 1 (each within the scatter of the next); then compound 2.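

At this position, para to a large group, the change from methoxy to chloro gives a 1.4-fold lower number from compound 1 to compound 4 (0.14 log units; within the scatter) in this assay. This step lies within the scatter, so the compounds show that on the core of compound 1 the two groups cannot be told apart in this assay, even though one oxygen-bearing group leaves and a single chlorine enters. Going by these compounds alone, the only earlier step on this ring, a 5.5-fold lower number from compound 2 to compound 3 (0.74 log units; beyond the scatter), set hydrogen against methyl on a different core and lay beyond the scatter, so it said nothing about this pair of groups. No evidence bearing on the reason for this result is available.

As far as these compounds go, whether an amine, a carboxylic acid or a longer chain at this position would also stay within the scatter of compound 1 remains open. From the compounds shown here alone, it is also open whether the step between methyl and hydrogen carries over to the core of compound 1.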